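This account rests on a few compounds, and the source may have more. Where it says the series, first, only, none or still open, it means among the compounds named here.

Measured so far in a functional assay for inhibition, with Homo sapiens as the target; on this read-out higher numbers stand for weaker inhibition and lower numbers for stronger inhibition:
- Compound 1 `O=C(O)COc1cccc(/C=C/c2nc(-c3ccccc3)c(-c3ccccc3)o2)c1` gives 13000 nM as its value
- Compound 2 `CCOC(=O)/C(=C/c1cccc(OCC(=O)OC)c1)c1nc(-c2ccccc2)c(-c2ccccc2)o1` gives 19700 nM as its value

Among the compounds with values here, these are the only two measurements. Within the data shown here, compound 1 at 13000 nM and compound 2 at 19700 nM lie within the usual scatter of each other, so compound 2 stands level with the one other measured compound.

The next compound, compound 3 `CCOC(=O)/C(=C\c1cccc(OCC(=O)OC)c1)c1nc(-c2ccccc2)c(-c2ccccc2)o1`, keeps everything in compound 2 except one feature: the two compounds have the same atoms and bonds and differ only in configuration as drawn: 1 of 1 stereo elements differ; a double bond is drawn E in compound 2 and Z in compound 3. The two have the same atoms and bonds, and the double bond is drawn E in compound 2 and Z in compound 3.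

Among the measured compounds shown here, no measured pair differs at this double bond alone, so the data do not show how much such a change can matter. With no such evidence, no step beyond the scatter is expected in this assay, in either direction, though a wide margin is warranted. The estimate means an expected 1.2-fold lower number from compound 2 to compound 3 (0.06 log units; within the scatter) in this measurement. For compound 3 the estimated value is 17000 nM, with an expected range from 6000 nM to 45000 nM for the result.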

Compound 3, half-maximal inhibitory concentration: 2000 nM
The estimate for compound 3 lay 8.5-fold (0.93 log units) above the measured number; the measured number lies below the stated range.
By their numbers in this assay, from the lowest: compound 3; then compounds 1 and 2 (each within the scatter of the next).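

In this assay, within the data shown here, the double bond carrying the ethyl ester proves to be a place where configuration alone can count: the change from E to Z gives a 9.9-fold lower number from compound 2 to compound 3 (0.99 log units; beyond the scatter), the only step that lies beyond the scatter. Among these compounds, until this result, no pair isolated this double bond, so the size of any such effect could not be seen. The step can be assigned to the configuration of the double bond and to nothing else, because no other difference separates the two compounds: the fact that compounds 2 and 3 differ only in the configuration as drawn

The compounds shown leave open whether the Z form keeps its advantage when the ethyl ester on the double bond gives way to another group, such as a nitrile or an amide. They also leave open what property of the Z form lies behind the step, and whether a similar step would appear in a measurement other than this assay or with a different group on the shared core.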